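A few compounds are considered here, and "the series" means these few. Any claim that something is new, unique, unknown or untested is made for them only; others in the source may bear on it.

Measured in an ADME assay on microsomes from liver (Homo sapiens) for pharmacokinetics; on this read-out lower numbers stand for slow clearance and higher numbers for fast clearance:
Compound 1 `CC(C)Oc1cc(-c2cncc(-c3cnn(C4COC4)c3)c2)ccc1C(N)=O`: < 10 mL.min-1.g-1 (a limit of the assay, not a number)
Compound 2 `Cc1c(-c2cncc(-c3ccc(C(N)=O)c(OC(C)C)c3)c2)cnn1C`: 7.9 mL.min-1.g-1

Among the compounds with values here, compound 2 carries the only true number in this small set, 7.9 mL.min-1.g-1. Compound 1 is known only from the limit of < 10 mL.min-1.g-1 in this assay, at which 1 of the 2 values shown sits.

The next compound to consider is compound 3 `CC(C)Oc1cc(-c2cccnc2)ccc1C(N)=O`. The change is hydrogen in place of 1,5-dimethyl-1H-pyrazol-4-yl on an aromatic carbon, so the group is removed rather than exchanged.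

Within the data shown here, only one measured step bears on this, a step that the limit leaves unreadable from compound 1 to compound 2. It exchanges one group for another at this place, and its size cannot be read, so it offers no measure of what removing the group does. Among the measured compounds shown here, no measured step removes the group, and the data give no direction in this assay. For the measured compounds named here, the only numerical anchor is compound 2 at 7.9 mL.min-1.g-1, so no step beyond the scatter is expected, though this expectation is weakly supported. The expected change is a 1.3-fold higher number from compound 2 to compound 3 (0.10 log units; within the scatter). For compound 3 the estimate is 10 mL.min-1.g-1, with an expected range from 5 mL.min-1.g-1 to 25 mL.min-1.g-1.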

Compound 3, intrinsic clearance in microsomes: 5.8 mL.min-1.g-1
The estimate for compound 3 lay 1.7-fold (0.24 log units) above the measured number; the range from low to high includes it.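

In this assay, within the data shown here, the first step that can be read at this position is a 1.4-fold lower number from compound 2 to compound 3 (0.13 log units; within the scatter), and it comes from removing the group rather than exchanging it. The 1,5-dimethyl-1H-pyrazol-4-yl group, with its five-membered aromatic ring, gives way to hydrogen on an aromatic carbon of the six-membered aromatic ring with 1 nitrogen, and the printed step stays within the scatter, so among these compounds this substituent is not needed for a number of this size. The steps that start from compound 1, which carries 1-(oxetan-3-yl)-1H-pyrazol-4-yl at this place, cannot be read: the limit of < 10 mL.min-1.g-1 in this assay, at which 1 of the 3 values shown sits.

The compounds shown leave open whether a different kind of group at this place, such as an amine or a carboxylic acid, would stay within the scatter of compound 3 or move beyond it. Among these compounds, with only one substituted compound carrying a true number at this position, they also leave open whether any group here can shift the number in this assay beyond the scatter at all.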